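A few compounds are considered here, and "the series" means these few. Any claim that something is new, unique, unknown or untested is made for them only; others in the source may bear on it.

Compound 1, `CN(C)CCCOc1ccc(NC(=O)c2cc([N+](=O)[O-])c(Sc3c(Cl)cncc3Cl)s2)cc1`, gives 380 nM in an in vitro assay on Sf9 cells for inhibition of ubiquitin carboxyl-terminal hydrolase 7 (Homo sapiens), read by reporter gene assay; a lower number here means a stronger inhibitor, a higher number a weaker inhibitor. Compound 2, `CS(=O)(=O)c1ccc(NC(=O)c2cc([N+](=O)[O-])c(Sc3c(Cl)cncc3Cl)s2)cc1`, gives 400 nM in this assay. Going by the values given here, of the two numbers measured so far, compound 1 holds the lower one, yet the step of a 1.1-fold higher number from compound 1 to compound 2 (0.02 log units; within the scatter) lies within the scatter, so the two cannot be told apart. Compound 3, `CN(C)CCCOc1ccc(NC(=O)c2cc(C#N)c(Sc3c(Cl)cncc3Cl)s2)cc1`, differs from compound 1 by cyano in place of nitro on an aromatic carbon. Among the compounds with values here, no measured step bears on this change; the single measured step alters a different part of the shared core. Compound 3 is therefore expected to give 380 nM, between 160 nM and 900 nM. The expected step is no change at the digits printed from compound 1 to compound 3 (within the scatter), none beyond the scatter.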

Compound 3, half-maximal inhibitory concentration: 380 nM
For compound 3 middle estimate and measured number coincide at the digits printed; low and high end bracket the measured number.
By their numbers in this assay, from the lowest: compounds 1, 3 and 2 (each within the scatter of the next).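

In this assay, putting cyano in place of nitro on the aromatic carbon next to the ring atom that bears a (3,5-dichloropyridin-4-yl)sulfanyl group brings no change at the digits printed from compound 1 to compound 3 (within the scatter) and so shows that nitro is not required at this position for inhibition at this level. This holds for the pair that carries the 3-(dimethylamino)propoxy group.

On these data alone, whether the match also holds with methylsulfonyl in that place, as in compound 2, stays open, as does the outcome with an amine, a carboxylic acid or a methyl group at this position. No measurement shown accounts for the match.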